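Extending the Tail Chain Toward the Phenyl Group

This account rests on a few compounds, and the source may have more. Where it says the series, first, only, none or still open, it means among the compounds named here.

compound 1 `O=C(O)CCC[C@H](O)[C@@H](/C=C\CCCCCCCCCOc1ccccc1)Sc1ccc(C(=O)O)cc1` — 316 nM
compound 2 `O=C(O)CCC[C@H](O)[C@@H](/C=C\CCCCCCCCCCCc1ccccc1)Sc1ccc(C(=O)O)cc1` — 1260 nM

In an assay on membranes from lung for binding affinity to cysteinyl leukotriene receptor 1 (Cavia porcellus) (on this read-out higher numbers stand for weaker inhibition and lower numbers for stronger inhibition), compound 2 stands highest of the two numbers shown, with compound 1 as its nearest neighbour. Compound 3 `O=C(O)CCC[C@H](O)[C@@H](/C=C\CCCCCCCCCCCCCc1ccccc1)Sc1ccc(C(=O)O)cc1` differs from compound 2 by phenethyl in place of phenyl on a saturated chain carbon, ten or more bonds along the chain from a double-bonded chain carbon. Going by the values given here, the only measured step that bears on this change is a 4.0-fold higher number from compound 1 to compound 2 (0.60 log units; beyond the scatter), in which a longer link to the phenyl group went with a higher number. A further step in the same direction, somewhat smaller, is expected here: a 2.0-fold higher number from compound 2 to compound 3 (0.30 log units; within the scatter). Compound 3 is therefore estimated at 2500 nM, within a range from 1000 nM to 6300 nM.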

Compound 3, inhibition constant: 5010 nM
Beside the measured number, compound 3's estimate is 2.0-fold (0.30 log units) below it, and the stated range covers the measured number.
By their numbers in this assay, from the lowest: compound 1; then compound 2; then compound 3.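

In this assay phenethyl in place of phenyl on this saturated chain carbon gave a 4.0-fold higher number from compound 2 to compound 3 (0.60 log units; beyond the scatter) and thus matched the earlier 4.0-fold higher number from compound 1 to compound 2 (0.60 log units; beyond the scatter) in size, so the rise did not level off at compound 2. Taken together, 4-phenylbutyl in place of phenoxy gave a 16-fold higher number from compound 1 to compound 3 (1.20 log units; beyond the scatter) and none of the three compounds goes against this climb as the link to the phenyl group lengthens. Nothing measured here explains the rise. Still open, from the compounds shown here alone, is whether a shorter chain would bring the number down, and how an amine or a carboxylic acid in place of the phenyl group would read.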